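Replacing the 4-chlorophenyl arm in a histamine agonist series

The compounds below may be only part of what the source reports. "The series", "measured", "known", "first", "only" and "open" are said of these compounds alone.

Of the compounds shown here, three built on a shared core have been measured in a functional assay on cardiac atrium for agonist activity at histamine H2 receptor (Cavia porcellus); a higher number here means a more potent compound, by a factor of ten per unit of this negative logarithm, a lower number a less potent compound. Compound 3 `N=C(NCCCc1c[nH]cn1)NCCC(c1ccc(Cl)cc1)c1ccccn1` gives 7.84, the highest of the three values. Compound 2 `Cc1ccc(C(CC/N=C(\N)NCCCc2c[nH]cn2)c2ccccn2)cc1` gives 7.71, a figure that lies within the usual scatter of the figure for compound 3, so the two cannot be ranked. Compound 1 `N=C(NCCCc1c[nH]cn1)NCCSC(c1ccccc1)c1ccccn1` gives 6.6, which stands well below compound 3, by a margin beyond the scatter.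

Compound 4 `N=C(NCCCc1c[nH]cn1)NCCC(c1ccccn1)c1ccccc1F` is the next compound to be measured. It differs from compound 3 in one place: 2-fluorophenyl in place of 4-chlorophenyl on a saturated chain carbon bound to an aromatic carbon and a saturated chain carbon. For the measured compounds named here, no pair of measured compounds shows this change on its own, and no measured compound carries a 2-fluorophenyl at all, so the size of the step has to be guessed. Going by the values given here, the only near comparison is compound 2, where a 4-methylphenyl in place of the 4-chlorophenyl of compound 3 left the value within the scatter.

On that basis compound 4 is expected to give 7.5, with a range from 6.9 to 8.1. The step of a number 0.34 log units lower from compound 3 to compound 4 (beyond the scatter) is thus estimated as a small loss, probably not beyond the scatter.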

Compound 4, negative logarithm of the half-maximal effective concentration: 7.46
Estimate against measurement, compound 4: 0.04 log units above; measured number inside the range.
By their numbers in this assay, from the lowest: compound 1; then compounds 4, 2 and 3 (each within the scatter of the next, the first and the last beyond it).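

In this assay, for the compounds shown here, 2-fluorophenyl in place of 4-chlorophenyl on a saturated chain carbon gives a number 0.38 log units lower from compound 3 to compound 4 (beyond the scatter), the first step at this position that can be read on its own, and it shows that this arm can be changed with a modest loss and a measurable effect on the number. Going by these compounds alone, compound 4 and compound 2 also differ only in this arm, yet compound 4 at 7.46 and compound 2 at 7.71 lie within the scatter of each other, so the 2-fluorophenyl and 4-methylphenyl arms cannot be ranked, and only the pair with the 4-chlorophenyl arm of compound 3 separates. Nothing available here accounts for the size of this step.

The change swaps the halogen and moves it on the ring at once, so a 4-fluorophenyl or a 2-chlorophenyl arm would be needed to tell these two parts apart. Also open, from the compounds shown here alone, is how an unsubstituted phenyl, or a phenyl carrying a methoxy group or an amine, would stand at this position.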